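The compounds below may be only part of what the source reports. "The series", "measured", "known", "first", "only" and "open" are said of these compounds alone.

Measured so far in an ADME assay on MDCKII-LE cells (Canis lupus familiaris) for permeability; on this read-out higher numbers stand for higher permeability and lower numbers for lower permeability:
compound 1 `Cc1cnc(NC(=O)c2cc(Oc3cnc(C(=O)N(C)C)cn3)c3cc(C)oc3c2)cn1` gives 22.3 10^-6 cm/s
compound 2 `Cc1cnc(NC(=O)c2cc(Oc3ccc(S(C)(=O)=O)cc3)c3cc(C)oc3c2)cn1` gives 7.6 10^-6 cm/s
compound 3 `Cc1cnc(NC(=O)c2cc(Oc3ncc(C(=O)N(C)C)cn3)c3cc(C)oc3c2)cn1` gives 34.7 10^-6 cm/s

These three compounds share a core and differ in the group attached to it through an ether oxygen. Compound 1 gives 22.3 10^-6 cm/s and stands level, within the scatter, with compound 3. It lies clearly above compound 2, the only one of the three set apart from it beyond the scatter.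

The next compound to be read is compound 4 `CNC(=O)c1cnc(Oc2cc(C(=O)Nc3cnc(C)cn3)cc3oc(C)cc23)cn1` and it differs from compound 1 at a single place: hydrogen in place of methyl on an amide-type nitrogen in words, hydrogen in place of methyl on an amide-type nitrogen, so that dimethylcarbamoyl becomes methylcarbamoyl.

Within the data shown here, no two measured compounds differ by this change, so the data offer no direct guide to its size in this assay and the expectation is a judgement. A modest fall is expected, of about the size of the scatter, and a result level with compound 1 would not surprise. The estimate is anchored on compound 1 at 22.3 10^-6 cm/s and its lower end reaches about as far as compound 2 at 7.6 10^-6 cm/s on this read-out. The expected change is a 1.7-fold lower number from compound 1 to compound 4 (0.23 log units; within the scatter) in this estimate. For compound 4 the expected value is 13 10^-6 cm/s with an estimated range from 6 10^-6 cm/s to 25 10^-6 cm/s for the measurement.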

Compound 4, apparent permeability: 20.9 10^-6 cm/s
Compound 4: middle estimate off by 1.6-fold (0.21 log units), on the low side, within the range that was stated.
By their numbers in this assay, from the lowest: compound 2; then compounds 4, 1 and 3 (each within the scatter of the next).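

Among these compounds, the first direct reading of hydrogen in place of methyl on an amide-type nitrogen, dimethylcarbamoyl becoming methylcarbamoyl, appears in this assay as a small step (a 1.1-fold lower number from compound 1 to compound 4 (0.03 log units; within the scatter)), so at this place the change leaves the number level with that of the parent. Exchanging the whole group on the ether oxygen is a different matter: with 5-(methylcarbamoyl)pyrazin-2-yl in place of 4-(methylsulfonyl)phenyl on an oxygen on an aromatic ring, the read-out shows a modest step beyond the scatter (a 2.8-fold higher number from compound 2 to compound 4 (0.44 log units; beyond the scatter)). No measured property is at hand to account for either step.

The compounds shown leave open how the number responds when the same nitrogen carries an ethyl group or a longer chain, or when the amide gives way to a carboxylic acid or a primary carboxamide. They also leave open whether hydrogen in place of methyl would read the same on the dimethylcarbamoyl group of compound 3, where the same exchange has no measured partner here.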